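The source may hold more compounds than are shown below. What is called first, only, known or untested is meant among the compounds shown, and "the series" means these compounds.

Measured so far in an ADME assay on HEL cells (Homo sapiens) for cytotoxicity, with a stated time of 3 days; a higher number here means that more compound is tolerated, a lower number that less compound is tolerated:
compound 1, `CCC1(Cc2ccccc2)OS(=O)(=O)C=C1OCCCCc1ccccc1`: >= 20000 nM, a limit of the assay and not a number.
compound 2, `CCC1(Cc2ccccc2)OS(=O)(=O)C=C1OCc1ccccc1Cl`: >= 20000 nM, also a limit.
compound 3, `CCC1(Cc2ccccc2)OS(=O)(=O)C=C1OCC1CCCCC1`: >= 200000 nM, again a limit.

Compound 1 thus stands only at the limit of >= 20000 nM in this assay, at which 2 of the 3 values shown sit. Compound 3 alone sits at the limit of >= 200000 nM in this assay, at which 1 of the 3 values shown sits. The steps a step that the two limits leave unreadable from compound 1 to compound 2 and a step that the two limits leave unreadable from compound 1 to compound 3 have no readable size, and the same holds for a step that the two limits leave unreadable from compound 2 to compound 3.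

Compound 4, `CCC1(Cc2ccccc2)OS(=O)(=O)C=C1OCCCCCCc1ccccc1`, differs from compound 1 by phenethyl in place of phenyl on a saturated chain carbon, four bonds along the chain from an oxygen on an unsaturated carbon. The two steps starting from compound 1 are the ones that bear on this change, and neither is readable, so no step beyond the scatter is expected in this assay in either direction. Compound 4 is therefore expected at 30000 nM, within 10000 nM to 200000 nM, most likely again reported only as a limit. The expected step that the limit leaves unreadable from compound 1 to compound 4 is essentially none.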

Compound 4, minimum cytotoxic concentration: >= 20000 nM
Compound 4 ended at the assay's limit; the forecaster's own chance of this, stated with the estimate: 85%; the middle value does not contradict the limit.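

In this assay, the step between compound 1 and compound 4 cannot be read, as both values are limits of the assay. The compounds shown leave open at what concentration any of them becomes cytotoxic, and whether the groups changed here alter that concentration.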